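A few compounds are considered here, and "the series" means these few. Any claim that something is new, unique, unknown or untested is made for them only; others in the source may bear on it.

Compound 1, `Nc1cc(N)c2nc(-c3ccccc3)c(Sc3ccc(F)cc3)nc2c1`, is the reference point of this account. In a functional assay on OVCAR-8 cells (Homo sapiens) for inhibition, read by sulforhodamine B assay, with a stated time of 48 h (on this read-out higher numbers stand for lower toxicity in this test and lower numbers for higher toxicity in this test), compound 1 gives 72400 nM, the highest of the two numbers reported in this assay. Its nearest neighbour is compound 2, `COc1cc(CNc2nc3cc(N)cc(N)c3nc2-c2ccccc2)cc(OC)c1OC`, which in this assay gives 31600 nM, a lower number than compound 1 and a gap that lies beyond the usual scatter. Compound 3, `CCOC(=O)[C@H](CCC(=O)O)NC(=O)c1ccc(CNc2nc3cc(N)cc(N)c3nc2-c2ccccc2)cc1`, reaches only a limit in this assay, < 100000 nM; (the limit of < 100000 nM in this assay, at which 1 of the 3 values shown sits). For the measured compounds named here, no pair of compounds here differs in a single place, so no measured step is available.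

The compound not yet measured is compound 4, `Nc1cc(N)c2nc(-c3ccccc3)c(NCc3ccc(F)cc3)nc2c1`. It differs from compound 1 at one position: (4-fluorobenzyl)amino in place of (4-fluorophenyl)sulfanyl on an aromatic carbon. Since compound 2, which also carries a benzylamino-type group on the shared core, gives 31600 nM, a lower number than compound 1, compound 4 is expected to follow the same direction. The step from compound 1 to compound 4 is estimated as a 2.1-fold lower number from compound 1 to compound 4 (0.32 log units; beyond the scatter), a moderate decrease. Compound 4 is thus expected to give about 35000 nM in this assay, within 12000 nM to 100000 nM.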

Compound 4, concentration lethal to 50% of the cells: 21900 nM
For compound 4 the middle estimate is 1.6-fold (0.20 log units) above the measured one; measured number inside the range.
By their numbers in this assay, from the lowest: compounds 4 and 2 (each within the scatter of the next); then compound 1.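

For the compounds shown here, this is the first step read at this position, on an aromatic carbon next to the ring nitrogen and ortho to a phenyl group. In this assay, (4-fluorobenzyl)amino in place of (4-fluorophenyl)sulfanyl gives a 3.3-fold lower number from compound 1 to compound 4 (0.52 log units; beyond the scatter), so this change at this position moves the number by more than the scatter, toward higher toxicity in this test. Nothing measured here gives a cause for this step.

The change swaps the sulfur for a nitrogen and also adds a carbon, and the compounds shown do not separate the two; a (4-fluorobenzyl)sulfanyl or a (4-fluorophenyl)amino group would. Also open, going by these compounds, is how the number responds at this position to a longer chain between the nitrogen and the ring, or to a chlorine in place of the fluorine.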